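Selenium replaced by sulfur on a quinoline-free core: expected loss

The compounds below may be only part of what the source reports. "The series", "measured", "known", "first", "only" and "open" are said of these compounds alone.

Measured so far:
compound 1 `OCC#CCSc1cnc2ccccc2c1[Se]CC#CCBr`: 2.8 ug/mL
compound 2 `OCC#CCSc1cnc2ccccc2c1SCC#CCBr`: 36.2 ug/mL
compound 3 `C#CCSc1cnc2ccccc2c1[Se]CC#CCBr`: 2.2 ug/mL

All three were tested in a functional assay on SW707 cells (Homo sapiens) for cytotoxicity, read by sulforhodamine B assay, with a stated time of 72 h; on this read-out higher numbers stand for weaker inhibition and lower numbers for stronger inhibition. Compound 3 gives 2.2 ug/mL, the lowest of the three numbers; its nearest neighbour is compound 1, separated by a 1.3-fold lower number from compound 1 to compound 3 (0.10 log units; within the scatter), while compound 2 stands far away at 36.2 ug/mL. Compound 4 `C#CCSc1cnc2ccccc2c1SCC#CCO` has not yet been measured. It differs from compound 3 in one place: a group of 6 heavy atoms (4 carbon, 1 oxygen, 1 sulfur; no ring) in place of a group of 6 heavy atoms (4 carbon, 1 selenium, 1 bromine; no ring), on an aromatic carbon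

Going by the values given here, one measured step bears directly on this change. Replacing the selenium-containing group with a sulfur-containing group gave a 13-fold higher number from compound 1 to compound 2 (1.11 log units; beyond the scatter). The other step, a 1.3-fold lower number from compound 1 to compound 3 (0.10 log units; within the scatter), shows that adding or removing a hydroxymethyl on a triple-bonded carbon barely moves the number. Compound 4 also swaps bromine for oxygen on the chain, for which no step is shown, but a large rise in the number is expected, driven by a 13-fold higher number from compound 1 to compound 2 (1.11 log units; beyond the scatter). Compound 4 is therefore estimated to give 28 ug/mL, between 9 ug/mL and 85 ug/mL, a step of a 13-fold higher number from compound 3 to compound 4 (1.10 log units; beyond the scatter) from compound 3.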

Compound 4, concentration for 50% inhibition: 42.6 ug/mL
Compound 4: middle estimate off by 1.5-fold (0.18 log units), on the low side; the range from low to high includes it.
By their numbers in this assay, from the lowest: compounds 3 and 1 (each within the scatter of the next); then compounds 2 and 4 (each within the scatter of the next).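

In this assay the large rise seen earlier also appears when the other chain is a propargylsulfanyl group, with a 19-fold higher number from compound 3 to compound 4 (1.29 log units; beyond the scatter) on an aromatic carbon ortho to that group. The earlier step of a 13-fold higher number from compound 1 to compound 2 (1.11 log units; beyond the scatter) came with a hydroxymethyl at the end of the other chain, so across these two pairs the rise does not depend on that hydroxymethyl. The entering group also carries oxygen rather than bromine, with 1 hydrogen-bond donor and 2 hydrogen-bond acceptors, and the number still stays high.

Selenium and bromine leave together here, so it takes a selenium chain ending in oxygen, or in an amine, to tell the effects of the two atoms apart. Nothing measured here explains why the number rises.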